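The source may hold more compounds than are shown below. What is called first, only, known or untested is meant among the compounds shown, and "the series" means these compounds.

Three compounds built on a shared core were tested for inhibition in a functional assay on MCF7 cells (Homo sapiens) for inhibition, read by MTT assay, with a stated time of 72 h; a higher number here means a weaker inhibitor, a lower number a stronger inhibitor. Compound 1 `COc1cc(NC(C)CCCNC(=O)NNC(=O)Nc2cccc(F)c2)c2ncccc2c1` gives 150 nM in this assay, compound 2 `COc1cc(NC(C)CCCNC(=O)Nc2ccc(F)cc2)c2ncccc2c1` gives 26000 nM, and compound 3 `COc1cc(NC(C)CCCNC(=O)NNC(=O)Nc2cccc(Cl)c2)c2ncccc2c1` gives 220 nM. Compound 3 thus holds the second highest of the three numbers. The step of a 1.5-fold higher number from compound 1 to compound 3 (0.17 log units; within the scatter) lies within the scatter. The step of a 120-fold lower number from compound 2 to compound 3 (2.07 log units; beyond the scatter) is large and beyond the scatter.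

Compound 4 `COc1cc(NC(C)CCCNC(=O)Nc2cccc(Cl)c2)c2ncccc2c1` has not yet been measured in this assay. It differs from compound 3 in one place: 3-chlorophenyl in place of ((3-chlorophenyl)carbamoyl)amino on an amide-type nitrogen. Within the data shown here, two measured steps bear on this change. The step of a 170-fold higher number from compound 1 to compound 2 (2.24 log units; beyond the scatter) made the corresponding change at the same amide-type nitrogen, and the step of a 120-fold lower number from compound 2 to compound 3 (2.07 log units; beyond the scatter) reversed it. Both were large and well beyond the scatter, so a step of similar size toward a higher number is expected for compound 4, namely a 110-fold higher number from compound 3 to compound 4 (2.06 log units; beyond the scatter). Compound 4 is therefore estimated at 25000 nM in this assay, with an expected range from 7000 nM to 90000 nM.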

Compound 4, half-maximal inhibitory concentration: 11000 nM
Compound 4: the middle estimate sits 2.3-fold (0.36 log units) above what was measured; the measured number falls inside the stated range.
By their numbers in this assay, from the lowest: compounds 1 and 3 (each within the scatter of the next); then compound 4; then compound 2.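

In this assay the swap of ((3-chlorophenyl)carbamoyl)amino for 3-chlorophenyl on the amide-type nitrogen gives a 50-fold higher number from compound 3 to compound 4 (1.70 log units; beyond the scatter) and so keeps the chlorinated aromatic ring on both sides of the change, which shows that the large loss follows the carbamoylamino part itself and is not tied to a change of ring substituent. The step that also changes fluoro to chloro, a 73-fold higher number from compound 1 to compound 4 (1.87 log units; beyond the scatter), points the same way. Among the compounds without that part, a 2.4-fold lower number from compound 2 to compound 4 (0.37 log units; beyond the scatter) is modest, so the choice between 3-chlorophenyl and 4-fluorophenyl weighs far less here than the presence of the carbamoylamino part.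

Nothing available explains why this part matters so much. On these data alone, it also remains open whether a simple amine or a carboxylic acid on the aromatic ring, or a longer carbon chain in place of the carbamoylamino part, would keep the low numbers of compound 1 and compound 3.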